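A few compounds are considered here, and "the series" means these few. Any claim that something is new, unique, unknown or untested is made for them only; others in the source may bear on it.

Compound 1 `CC1CCN(C2CCN(S(=O)(=O)c3cccc(-c4ccccc4C(F)(F)F)c3)CC2)CC1`: > 5000 nM
Compound 2 `Cc1cc(C)c(S(=O)(=O)N2CCC(C3OCC(C)CO3)CC2)c(C)c1`: > 5000 nM

Both results come from an ADME assay on HCT-116 cells (Homo sapiens) for cytotoxicity, read by CellTiter-Glo, with a stated time of 72 h; a lower number here means a stronger inhibitor, a higher number a weaker inhibitor. For compound 1 the value > 5000 nM is a limit, not a number. For compound 2 the value > 5000 nM is likewise only a limit. Compound 1 therefore stands at the limit of > 5000 nM in this assay, at which 2 of the 2 values shown sit, with nothing to rank it against. Compound 3 `CC1CCN(C2CCN(S(=O)(=O)c3cccc(-c4ccc(F)cc4)c3)CC2)CC1` has not yet been tested; it differs from compound 1 by 4-fluorophenyl in place of 2-(trifluoromethyl)phenyl on an aromatic carbon. For the measured compounds named here, no measured step is known here, so no movement beyond the scatter is expected, estimated as a step that the limit leaves unreadable from compound 1 to compound 3. Compound 3 is expected at 8000 nM, between 2000 nM and 30000 nM.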

Compound 3, half-maximal inhibitory concentration: > 5000 nM
Compound 3 ended at the assay's limit; the forecaster's own chance of this, stated with the estimate: 65%; the middle value does not contradict the limit.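

For the compounds shown here, compound 1 and compound 3 each give only a limit in this assay and not a number, so no step between them can be read. The compounds shown leave open what their true values are, and whether 4-fluorophenyl in place of 2-(trifluoromethyl)phenyl changes them at all.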